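Enlarging the Ring on the Amide of Compound 3

A few compounds are considered here, and "the series" means these few. Any claim that something is new, unique, unknown or untested is made for them only; others in the source may bear on it.

Three measured compounds share one core and differ only in the group on the ring nitrogen. Compound 1 `CCN1CCc2nc(C#Cc3ccccc3)sc2C1` carries an ethyl there, and in an assay on HEK293 cells for negative allosteric modulation of metabotropic glutamate receptor 5 (Homo sapiens), read by FLIPR, with a stated time of 1 h (on this read-out lower numbers stand for stronger inhibition and higher numbers for weaker inhibition), compound 1 gives 1200 nM. Compound 2 `CC(=O)N1CCc2nc(C#Cc3ccccc3)sc2C1` carries an acetyl instead; compound 2 gives 90 nM, a step of a 13-fold lower number from compound 1 to compound 2 (1.12 log units; beyond the scatter). Compound 3 `CC1CC1C(=O)N1CCc2nc(C#Cc3ccccc3)sc2C1` carries a (2-methylcyclopropyl)carbonyl. For compound 3 the assay reports only a limit, > 10000 nM, so compound 3 sits at the limit of > 10000 nM in this assay, at which 1 of the 3 values shown sits. The steps to it were an at least 8.3-fold higher number from compound 1 to compound 3 (0.92 log units; beyond the scatter) and an at least 110-fold higher number from compound 2 to compound 3 (2.04 log units; beyond the scatter).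

Compound 4 `CC1CC(C(=O)N2CCc3nc(C#Cc4ccccc4)sc3C2)C1` differs from compound 3 in one place: 3-methylcyclobutyl in place of 2-methylcyclopropyl on a carbonyl carbon. The step that bears on this is the large loss seen from compound 2 to compound 3 when the group on the carbonyl carbon grew from methyl to a methylcyclopropyl; compound 4 grows this group further. For the measured compounds named here, no measured pair compares two ring sizes here. Compound 4 is therefore expected to remain at or beyond the limit, a step that the limit leaves unreadable from compound 3 to compound 4 within the scatter. The estimate for compound 4 is 15000 nM, between 5000 nM and 50000 nM.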

Compound 4, half-maximal inhibitory concentration: > 10000 nM
Compound 4: no number, only a limit; the forecaster's own chance of this, stated with the estimate: 70%; the middle value does not contradict the limit.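

In this assay compound 4 gives only a limit, > 10000 nM, and no number. Its loss against the acetyl amide of compound 2 is as large as any that can be read here, with an at least 110-fold higher number from compound 2 to compound 4 (2.04 log units; beyond the scatter), and the loss against the ethyl of compound 1 stands as well, with an at least 8.3-fold higher number from compound 1 to compound 4 (0.92 log units; beyond the scatter). The step between compound 3 and compound 4 cannot be read, but the loss is now seen with a second ring size and is no longer tied to the 2-methylcyclopropyl group alone: the limit of > 10000 nM in this assay, at which 2 of the 4 values shown sit.

The compounds shown leave open how large the group on the carbonyl carbon can grow from methyl before the loss sets in. They also leave open whether a plain cyclopropyl, a propyl chain or a methoxymethyl group there would keep the strength of compound 2.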